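This account rests on a few compounds, and the source may have more. Where it says the series, first, only, none or still open, it means among the compounds named here.

Four adenosine-derived compounds make up this small set. Compound 1 `Nc1ncnc2c1ncn2[C@@H]1O[C@H](CSCCCC(=O)O)[C@@H](O)[C@H]1O` and compound 2 `NCCCSC[C@H]1O[C@@H](n2cnc3c(N)ncnc32)[C@H](O)[C@@H]1O` carry a sulfur-linked side chain; in an assay for inhibition of tRNA (cytosine(38)-C(5))-methyltransferase (Homo sapiens), with a stated time of 5 min, tested at 100 uM (a lower number here means less inhibition, a higher number more inhibition at the concentration tested (going by the name of the read-out)), compound 1 gives no result reported and compound 2 gives no result reported. Among the compounds with values here, compound 3 `Nc1ncnc2c1ncn2[C@@H]1O[C@H](CN(CC[C@H](N)C(=O)O)CC2CC2)[C@@H](O)[C@H]1O` is the one compound with a number: in this assay compound 3 gives 27.5%, so it stands alone, with nothing to compare against. Compound 4 `C#CCCN(CC[C@H](N)C(=O)O)C[C@H]1O[C@@H](n2cnc3c(N)ncnc32)[C@H](O)[C@@H]1O` differs from compound 3 in a single place: propargyl in place of cyclopropyl on a saturated chain carbon bound to an amine nitrogen. Within the data shown here, no step between measured compounds exists to say what such an exchange does. A swap of this size is expected to move the reading no further than the scatter, in either direction. For compound 4 the inhibition in this assay is therefore estimated at 25%, in a range from 8% to 45%, a step of a number 2.5 percentage points lower from compound 3 to compound 4 (within the scatter) that is expected to stay within the usual scatter.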

Compound 4, a percentage reported as inhibition, at one concentration (the size of the read-out at that concentration, not a potency): 30.2%
Beside the measured number, compound 4's estimate is 5.2 percentage points below it; low and high end bracket the measured number.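

This place now has its first readable step: in this assay, propargyl in place of cyclopropyl gives a number 2.7 percentage points higher from compound 3 to compound 4 (within the scatter). Opening the three-membered ring's carbons into a chain with a triple bond, with the heavy-atom count unchanged, therefore makes no readable difference at this place at the concentration tested. Nothing measured here offers an explanation. As far as these compounds go, whether a benzyl group or a longer chain such as hexyl on the same nitrogen would move the reading beyond the scatter remains open. So does whether a carboxylic acid at the end of that chain would.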